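Sulfonamide series, aromatase inhibition: from compound 2 to compound 4

The source may report more compounds than this note shows. Statements on the series, on what has been measured and on what is new or still open speak of the compounds shown alone.

Measured so far in an assay on isolated protein for inhibition of Aromatase (Homo sapiens), tested at 1 uM; on this read-out lower numbers stand for less inhibition and higher numbers for more inhibition at the one concentration tested (going by the name of the read-out):
compound 1 `CC(C)CC1n2cncc2CN(Cc2ccc(F)cc2)S1(=O)=O` gives 39%
compound 2 `COC(C)(C)CC1n2cncc2CN([C@@H](C)c2ccc(Cl)cc2)S1(=O)=O` gives 17%
compound 3 `CC(C)CC1n2cncc2CN(CC2CC2)S1(=O)=O` gives 19%

Compound 2 gives the lowest of the three numbers in this assay. Compound 3 lies within the scatter of it, so no order between the two can be read; compound 1 stands beyond the scatter, higher. Within the data shown here, the single step between compounds that differ in one place is a number 20 percentage points lower from compound 1 to compound 3 (beyond the scatter), and it concerns the group on the saturated chain carbon bound to the sulfonamide nitrogen in the ring.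

Compound 4 `CC(C)OCC1n2cncc2CN([C@@H](C)c2ccc(Cl)cc2)S1(=O)=O` differs from compound 2 elsewhere: isopropoxy in place of 1-methoxy-1-methylethyl on a saturated chain carbon bound to a saturated ring carbon. Among the measured compounds shown here, no measured pair in this set changes that part of the molecule, so there is no step whose size can be carried over. The compounds with the unchanged 1-methoxy-1-methylethyl group, compound 2 and compound 3, sit within the scatter of each other, while the difference to compound 1 arises at the sulfonamide nitrogen, not at the chain carbon in question.

With nothing to point either way, the expected step is no change at the digits printed from compound 2 to compound 4 (within the scatter), that is, none beyond the scatter. Compound 4 is therefore estimated at 17% in this assay, within 4% to 32%.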

Compound 4, a percentage reported as inhibition, at one concentration (the size of the read-out at that concentration, not a potency): 23%
Compound 4: middle estimate off by 6 percentage points, on the low side; the range from low to high includes it.
By their numbers in this assay, from the lowest: compounds 2, 3 and 4 (each within the scatter of the next); then compound 1.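

Isopropoxy in place of 1-methoxy-1-methylethyl is the first change in the series on a saturated chain carbon bound to a saturated ring carbon, and in this assay it gives a number 6 percentage points higher from compound 2 to compound 4 (within the scatter). No order can therefore be read between compound 2 and compound 4, so this position accepts the exchange of these two groups, which goes from 5 heavy atoms to 4 and keeps 1 hydrogen-bond acceptor, without a step beyond the scatter in this read-out. There is no supporting evidence that could explain this outcome or connect it to any property of either group.

Still open, as far as these compounds go, is whether a different kind of group at this place, such as an amine, a carboxylic acid or a longer chain, would shift the number beyond the scatter. Also open, from the compounds shown here alone, is whether the exchange of 1-methoxy-1-methylethyl for isopropoxy would read the same way with the 4-fluorophenyl group of compound 1 on the chain carbon bound to the sulfonamide nitrogen.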